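Lengthening the ether chain on the shared core

The source may hold more compounds than are shown below. What is called first, only, known or untested is meant among the compounds shown, and "the series" means these compounds.

Measured so far:
Compound 1 `CN(C)CCNc1ccnc2cc(OCc3ccc(F)cc3)ccc12` gives 370 nM in a functional assay on HCT-116 cells (Homo sapiens) for cytotoxicity, read by MTT assay, with a stated time of 48 h; a lower number here means a stronger inhibitor, a higher number a weaker inhibitor.
Compound 2 `CCOc1ccc2c(NCCN(C)C)ccnc2c1` gives 2570 nM in this assay.

Going by the values given here, compound 2 has the highest of the two numbers, and its nearest neighbour is compound 1, reached by the single measured step of a 6.9-fold higher number from compound 1 to compound 2 (0.84 log units; beyond the scatter). Compound 3 `CCCCCCOc1ccc2c(NCCN(C)C)ccnc2c1` has not yet been measured. It differs from compound 2 by butyl in place of hydrogen on a saturated chain carbon, two bonds along the chain from an oxygen on an aromatic ring, so the ethoxy of compound 2 becomes a hexyloxy. Among the compounds with values here, the only step that bears on this change is a 6.9-fold higher number from compound 1 to compound 2 (0.84 log units; beyond the scatter), where a larger group at this oxygen gave a lower number; a longer chain is not an aromatic ring, so that step is only a rough guide. A modest drop in this assay is expected for compound 3, of about a 2.3-fold lower number from compound 2 to compound 3 (0.37 log units; beyond the scatter). Compound 3 is therefore estimated at 1100 nM, within a range of 350 nM to 3500 nM.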

Compound 3, half-maximal inhibitory concentration: 850 nM
For compound 3 the middle estimate is 1.3-fold (0.11 log units) above the measured one; measured number inside the range.
By their numbers in this assay, from the lowest: compound 1; then compound 3; then compound 2.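

In this assay, extending the ethoxy to a hexyloxy gives a 3.0-fold lower number from compound 2 to compound 3 (0.48 log units; beyond the scatter), so a plain open chain at this oxygen can lower the number without any aromatic ring. The chain does not fully match the ring-bearing group, however: replacing 4-fluorophenyl with pentyl at the chain carbon bound to the oxygen gives a 2.3-fold higher number from compound 1 to compound 3 (0.36 log units; beyond the scatter), so the group in compound 1 remains the better of the three in this assay. Nothing available here explains either shift.

From the compounds shown here alone, with only the ethoxy and the hexyloxy chains to compare, it remains open whether the number falls steadily with length or has a best length, which a butoxy or an octyloxy chain could show. Also open, going by these compounds, is how an amine at the end of the chain would fare.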